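A few compounds are considered here, and "the series" means these few. Any claim that something is new, unique, unknown or untested is made for them only; others in the source may bear on it.

Compound 1 `Cc1ncnc2c1c(-c1ccsc1)cn2[C@@H]1O[C@H](CO)[C@@H](O)[C@H]1O`: 320 nM
Compound 2 `Nc1nc(N)c2c(-c3ccccc3)cn([C@@H]3O[C@H](CO)[C@@H](O)[C@H]3O)c2n1`: > 20000 nM (a limit)
Compound 3 `Cc1nc(N)c2c(-c3ccccc3)cn([C@@H]3O[C@H](CO)[C@@H](O)[C@H]3O)c2n1`: > 20000 nM (a limit)

Of the compounds shown here, three have been measured in a functional assay on K562 cells (Homo sapiens), read by MTT assay, with a stated time of 72 h; on this read-out lower numbers stand for stronger inhibition and higher numbers for weaker inhibition. Compound 1 gives 320 nM. For compound 2 the assay reports only a limit, > 20000 nM. For compound 3 the assay also reports only a limit, > 20000 nM. Going by the values given here, the single step between compounds differing in one place, a step that the two limits leave unreadable from compound 2 to compound 3, joins two such limits and so has no readable size; both values sit at the limit of > 20000 nM in this assay, at which 2 of the 3 values shown sit. Compound 3 therefore stands at that limit, without a number of its own, and shares it with compound 2.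

Compound 4 `Cc1nc(N)c2c(-c3ccco3)cn([C@@H]3O[C@H](CO)[C@@H](O)[C@H]3O)c2n1` has not yet been measured. It differs from compound 3 by furan-2-yl in place of phenyl on an aromatic carbon. Among the compounds with values here, no measured step bears on this change: the one step measured, a step that the two limits leave unreadable from compound 2 to compound 3, concerns another part of the shared core, and compound 1 differs from the other compounds in more than one place, so its value forms no step. Within the data shown here, with compound 3 at a limit and no comparable step to read, the expected step is a number no higher from compound 3 to compound 4 (the limit leaves the size open), no change beyond the scatter. The estimate for compound 4 in this assay is 20000 nM, with a range from 4000 nM to 60000 nM, and most likely again only a limit.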

Compound 4, half-maximal inhibitory concentration: > 20000 nM
Compound 4 gave a limit, no number (the forecaster's own chance of this, stated with the estimate: 70%); the middle value lies on the limit itself.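

In this assay compound 3 and compound 4 each give only a limit, so no step between them can be read: the limit of > 20000 nM in this assay, at which 3 of the 4 values shown sit.

What the compounds shown leave open is whether furan-2-yl in place of phenyl changes the read-out at all; neither compound 3 nor compound 4 has a number of its own.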